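The source may report more compounds than this note shows. Statements on the series, on what has been measured and on what is new or still open speak of the compounds shown alone.

In a functional assay on the whole organism with Mus musculus as the target (on this read-out higher numbers stand for an effect only at larger amounts of compound and lower numbers for an effect already at smaller amounts), compound 1 `CCc1c(OC)nc2nc(-c3noc(C)n3)cn2c1C` gives 17 mg/kg. Compound 2 `CCCc1c(OC)nc2nc(-c3noc(C)n3)cn2c1C` gives 16.5 mg/kg. The chain extension between them is a 1.0-fold lower number from compound 1 to compound 2 (0.01 log units; within the scatter).

Compound 3 `CCc1c(OC)nc2nc(-c3nnc(C)o3)cn2c1C` is reported only as a limit, > 200 mg/kg. It therefore stands apart from the two measured numbers, and the exchange of its oxadiazole group is an at least 11-fold higher number from compound 1 to compound 3 (1.07 log units; beyond the scatter).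

Compound 4 `CCc1c(OC)nc2nc(-c3nc(C)no3)cn2c1C` keeps the core of compound 3 and differs only in that group: 3-methyl-1,2,4-oxadiazol-5-yl in place of 5-methyl-1,3,4-oxadiazol-2-yl on an aromatic carbon. The 3-methyl-1,2,4-oxadiazol-5-yl group has the same atoms as the group it replaces, joined differently. It shares its ring name with the 5-methyl-1,2,4-oxadiazol-3-yl group of compound 1, although it is not the same group.

The step that bears most directly is an at least 11-fold higher number from compound 1 to compound 3 (1.07 log units; beyond the scatter), and the new group should recover much of that loss, though probably not all of it. The chain step offers no guide here.

The expected change is a large move towards smaller doses, estimated as an at least 5.7-fold lower number from compound 3 to compound 4 (0.75 log units; beyond the scatter). Compound 4 is estimated at 35 mg/kg, with an expected range of 10 mg/kg to 150 mg/kg.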

Compound 4, dose for half-maximal effect: > 100 mg/kg
Compound 4: no number, only a limit; the forecaster's own chance of this, stated with the estimate: 20%; middle value at least 2.8-fold (0.45 log units) away from the limit.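

Compound 4 is known only as a limit: the limit of > 100 mg/kg in this assay, at which 1 of the 4 values shown sits.

Even so, the exchange gives an at least 5.8-fold higher number from compound 1 to compound 4 (0.76 log units; beyond the scatter) in this assay, so on this aromatic carbon, sharing the ring name of the group in compound 1 does not preserve the dose of compound 1. Of the three oxadiazole groups shown, only 5-methyl-1,2,4-oxadiazol-3-yl, carried by compound 1 and compound 2, gives a measured dose rather than a limit.

On these data alone, the step between compound 3 and compound 4 cannot be read, both values being limits, so the order of their two groups stays open. Also open, as far as these compounds go, is how a different group on this aromatic carbon, such as a methyl ester or a 1,2,4-triazole, would compare with the 5-methyl-1,2,4-oxadiazol-3-yl group.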